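Diaminoquinoxaline series: aryl ether to aryl thioether swap

The source may report more compounds than this note shows. Statements on the series, on what has been measured and on what is new or still open speak of the compounds shown alone.

Compound 1 `Nc1cc(N)c2nc(-c3ccccc3)c(Oc3ccc(Cl)c(Cl)c3)nc2c1`: in a functional assay on UO-31 cells (Homo sapiens) for inhibition, read by sulforhodamine B assay, with a stated time of 48 h (on this read-out higher numbers stand for weaker inhibition of growth and lower numbers for stronger inhibition of growth), compound 1 gives < 100000 nM, a limit of the measurement rather than a number.
Compound 2 `Nc1cc(N)c2nc(-c3ccccc3)c(NCc3ccc(Cl)c(Cl)c3)nc2c1`: in this assay compound 2 gives < 100000 nM, again a limit.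
Compound 3 `CCOC(=O)[C@H](CCC(=O)O)NC(=O)c1ccc(Sc2nc3cc(N)cc(N)c3nc2-c2ccccc2)cc1`: in this assay compound 3 gives < 100000 nM, also a limit.

Compound 1 therefore stands at the limit of < 100000 nM in this assay, at which 3 of the 3 values shown sit, with no number that sets it apart from compound 2 or compound 3. Compound 4 `Nc1cc(N)c2nc(-c3ccccc3)c(Sc3ccc(F)cc3)nc2c1` carries (4-fluorophenyl)sulfanyl in place of 3,4-dichlorophenoxy on an aromatic carbon. Among the compounds with values here, no measured step is available to calibrate this change, so no direction can be read from the data; the step from compound 1 to compound 4 is expected to stay within the scatter, as a step that the limit leaves unreadable from compound 1 to compound 4. Compound 4 is expected to give 30000 nM in this assay, within 5000 nM to 100000 nM, most likely reported as a limit.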

Compound 4, concentration for total growth inhibition: < 100000 nM
Compound 4: a limit, no number; the forecaster's own chance of this, stated with the estimate: 70%; the middle value does not contradict the limit.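

Compound 4 gives a limit, not a number, as does compound 1, so no step between compound 1 and compound 4 can be read: the limit of < 100000 nM in this assay, at which 4 of the 4 values shown sit.

The compounds shown leave open whether (4-fluorophenyl)sulfanyl in place of 3,4-dichlorophenoxy alters the result in this assay.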